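Aryl ketone para substituent: phenyl to trifluoromethyl

The source may report more compounds than this note shows. Statements on the series, on what has been measured and on what is new or still open speak of the compounds shown alone.

Measured so far in a functional assay on PC-3 cells (Homo sapiens) for inhibition, read by sulforhodamine B assay, with a stated time of 48 h, tested at 10 uM; on this read-out higher numbers stand for more inhibition of growth at the one concentration tested and lower numbers for less inhibition of growth:
compound 1, `CC(=O)c1cccc(Nc2ccnc(SCC(=O)c3ccc(-c4ccccc4)cc3)n2)c1`: 25%
compound 2, `CC(=O)c1ccc(Nc2ccnc(SCC(=O)c3ccc(Cl)cc3)n2)cc1`: 30%
compound 3, `CC(=O)c1ccc(Nc2ccnc(SCC(=O)c3ccc(-c4ccccc4)cc3)n2)cc1`: 19%

Compound 1 sits between the other two on these numbers. Its gap to compound 2 is within the scatter, and its step to compound 3 is a number 6 percentage points lower from compound 1 to compound 3 (within the scatter), also within the scatter, so the three measured compounds are close to one another.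

Compound 4, `CC(=O)c1cccc(Nc2ccnc(SCC(=O)c3ccc(C(F)(F)F)cc3)n2)c1`, differs from compound 1 in one place: trifluoromethyl in place of phenyl on an aromatic carbon. Among the measured compounds shown here, no measured step removes a phenyl from that carbon directly. The nearest comparison is the reverse of the step of a number 11 percentage points lower from compound 2 to compound 3 (beyond the scatter), where a small substituent on that ring gave way to phenyl and the number fell modestly; taking the phenyl away again and placing another small group there may therefore recover part of that loss. The acetyl position on the aniline ring is not expected to matter here, because the step of a number 6 percentage points lower from compound 1 to compound 3 (within the scatter) is within the scatter.

The step is therefore expected to be a number 8 percentage points higher from compound 1 to compound 4 (within the scatter), a modest rise at most. For compound 4 the estimate in this assay is 33%, with a range from 15% to 50%.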

Compound 4, percent growth inhibition at one concentration: 30%
The estimate for compound 4 lay 3 percentage points above the measured number; measured number inside the range.
By their numbers in this assay, from the lowest: compounds 3, 1, 2 and 4 (each within the scatter of the next, the first and the last beyond it).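

At this aromatic carbon, para to a large group, trifluoromethyl in place of phenyl gives a number 5 percentage points higher from compound 1 to compound 4 (within the scatter) in this assay, so a whole six-membered aromatic ring of carbon can leave this place without a shift beyond the scatter. Until now this carbon had been read only on the 4-acetylphenyl side, through a number 11 percentage points lower from compound 2 to compound 3 (beyond the scatter); compound 4 adds a one-place change on the 3-acetylphenyl side, and that change does not show the same size of step beyond the scatter, though two single steps on different partners do not establish a rule for this position. Nothing at hand explains the outcome at this carbon, and no measured property of either group bears on it.

Still open, as far as these compounds go, is whether a group of a different kind on this carbon, such as an amine, a carboxylic acid or a longer alkyl chain, would move the number beyond the scatter in this assay. Also open, from the compounds shown here alone, is whether the small differences seen at one concentration would hold across a full concentration range, and whether chloro on the 3-acetylphenyl side would read like trifluoromethyl.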